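This account rests on a few compounds, and the source may have more. Where it says the series, first, only, none or still open, it means among the compounds named here.

- compound 1 `CCC(=O)Nc1ccc(C2=NNC(=O)CC2)cc1`: 0.64 ug/mL
- compound 2 `CC(=O)Nc1ccc(C2=NN(C)C(=O)CC2)cc1`: > 46.4 ug/mL (a limit)
- compound 3 `Nc1cccc(C2=NNC(=O)CC2)c1`: > 46.4 ug/mL (a limit)

Going by the values given here, in a functional assay for inhibition, with Homo sapiens as the target (a higher number here means that more compound is needed for the effect, a lower number that less compound is needed), compound 1 gives 0.64 ug/mL, the only actual number. The other two readings are limits, not numbers: the limit of > 46.4 ug/mL in this assay, at which 2 of the 3 values shown sit.

Compound 4 `CCC(Cl)C(=O)Nc1ccc(C2=NNC(=O)CC2)cc1` keeps the core of compound 1 and changes one group: a group of 4 heavy atoms (3 carbon, 1 chlorine; no ring) in place of a group of 2 heavy atoms (2 carbon; no ring), on a carbonyl carbon. Among the compounds with values here, no measured pair isolates a change of this kind, so the size of the step has little support. No step beyond the scatter is expected, with a slight lean toward a higher number. The estimated change is a 1.4-fold higher number from compound 1 to compound 4 (0.15 log units; within the scatter). Compound 4 is expected at 0.9 ug/mL, with an estimated range of 0.12 ug/mL to 6.5 ug/mL.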

Compound 4, half-maximal effective concentration: 1.47 ug/mL
Beside the measured number, compound 4's estimate is 1.6-fold (0.21 log units) below it, and the stated range covers the measured number.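

In this assay the carbonyl carbon accepts a chlorine-bearing group in place of ethyl and still gives a measured number rather than a limit, with a 2.3-fold higher number from compound 1 to compound 4 (0.36 log units; beyond the scatter) as a modest step. Going by these compounds alone, this is the only step at this position with a number on both sides. Nothing shown explains the step.

Still open, from the compounds shown here alone, is whether the step follows the chlorine or the longer chain, which a propyl group without chlorine would separate. Going by these compounds, how an amine on the same chain would read also remains open.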